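The compounds below may be only part of what the source reports. "The series", "measured", "known", "first", "only" and "open" are said of these compounds alone.

Compound 1 `O=C(O)CC(O)(CSCCCCCCc1ccc(F)cc1)C(=O)O` and compound 2 `NS(=O)(=O)c1ccc(CCCCCCSCC(O)(CC(=O)O)C(=O)O)cc1` share a core that ends in an aromatic ring bearing a single substituent. Among the compounds with values here, in an assay on isolated protein for inhibition of ATP-citrate synthase (Rattus norvegicus) (a lower number here means a stronger inhibitor, a higher number a weaker inhibitor), compound 1 gives 120000 nM, and compound 2 gives 500000 nM, the highest of the two numbers known. Within the data shown here, the only change between them is a 4.2-fold higher number from compound 1 to compound 2 (0.62 log units; beyond the scatter). Compound 3 `O=C(O)CC(O)(CSCCCCCCc1ccc(C(=O)O)cc1)C(=O)O` keeps the same core and differs from compound 2 by carboxy in place of sulfamoyl on an aromatic carbon. Among the measured compounds shown here, the one step available for comparison is the replacement of fluoro by sulfamoyl, which raised the number modestly in this assay. Both sulfamoyl and carboxy bring a hydrogen-bond donor to that aromatic carbon, so a step comparable to the scatter, in either direction, is expected here. For compound 3 the expected step is no change at the digits printed from compound 2 to compound 3 (within the scatter), giving an estimate of 500000 nM, with a likely range from 150000 nM to 1500000 nM.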

Compound 3, inhibition constant: 420000 nM
For compound 3 the middle estimate is 1.2-fold (0.08 log units) above the measured one; low and high end bracket the measured number.
By their numbers in this assay, from the lowest: compound 1; then compounds 3 and 2 (each within the scatter of the next).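

In this assay, there is a 1.2-fold lower number from compound 2 to compound 3 (0.08 log units; within the scatter) when sulfamoyl gives way to carboxy, para to a large group, so the data do not separate these two groups. Carboxy in place of fluoro gives a 3.5-fold higher number from compound 1 to compound 3 (0.54 log units; beyond the scatter), which means that compound 1, with fluoro, now has a lower number than both compounds carrying a group with a hydrogen-bond donor, not just one. Nothing measured here explains why these numbers fall as they do.

The compounds shown leave open whether a chlorine atom, a methyl group or a plain hydrogen at this position would give a number nearer that of compound 1 or nearer those of compounds 2 and 3. They also leave open whether an amine there would match carboxy and sulfamoyl, and whether a shorter or longer chain would change the effect of these groups.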